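From Methoxyethyl Amide to Dihydroxypropyl Amide

The source may hold more compounds than are shown below. What is called first, only, known or untested is meant among the compounds shown, and "the series" means these compounds.

Compound 1 `COc1cccc2cc(C(=O)NCC(=O)O)c(=O)oc12`: 15%
Compound 2 `COCCNC(=O)c1cc2cccc(OC)c2oc1=O`: 0%

Of the compounds shown here, two have been measured in an assay on HeLa cells for displacement of a labelled ligand from adenosine receptor A3 (Homo sapiens), read by scintillation counting, with a stated time of 180 min, tested at 10 uM; on this read-out lower numbers stand for less inhibition and higher numbers for more inhibition at the one concentration tested (going by the name of the read-out). Among the measured compounds shown here, compound 1 gives 15%, and compound 2 gives 0%, the lowest of the two numbers; the one step of a number 15 percentage points lower from compound 1 to compound 2 (beyond the scatter) separates them. Compound 3 `COc1cccc2cc(C(=O)NCC(O)CO)c(=O)oc12` differs from compound 2 by 1,2-dihydroxyethyl in place of methoxymethyl on a saturated chain carbon bound to an amide-type nitrogen. For the measured compounds named here, only that measured step bears on the change, it was modest, and it concerned a different entering group, so it gives little guidance. No step beyond the scatter is therefore expected. Compound 3 is estimated at 5%, with a range from -5% to 20%, an expected step of a number 5 percentage points higher from compound 2 to compound 3 (within the scatter).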

Compound 3, a percentage reported as inhibition, at one concentration (the size of the read-out at that concentration, not a potency): 1%
Compound 3: middle estimate off by 4 percentage points, on the high side; the measured number falls inside the stated range.
By their numbers in this assay, from the lowest: compounds 2 and 3 (each within the scatter of the next); then compound 1.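

In this assay, 1,2-dihydroxyethyl in place of methoxymethyl on a saturated chain carbon bound to an amide-type nitrogen gives a number 1 percentage points higher from compound 2 to compound 3 (within the scatter), so these two groups cannot be told apart here. Set against carboxy, 1,2-dihydroxyethyl gives a number 14 percentage points lower from compound 1 to compound 3 (beyond the scatter), which leaves compound 1 alone above the other two compounds, whether methoxymethyl or 1,2-dihydroxyethyl is the group that replaces carboxy. Nothing available explains these numbers. Still open, on these data alone, is whether an amine, or a longer chain ending in a carboxylic acid, would read like compound 1 or like compound 2 and compound 3.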